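Fluoro for Chloro, Carried From One Sulfonyl Core to Another

The source may report more compounds than this note shows. Statements on the series, on what has been measured and on what is new or still open speak of the compounds shown alone.

Measured compounds:
compound 1, `Cc1ccc(S(=O)(=O)c2cnc3c(F)cccc3c2-c2ccc(F)cc2)cc1F`: 2.75 mL/min
compound 2, `Cc1ccc(S(=O)(=O)c2cnc3c(F)cccc3c2-c2ccc(Cl)cc2)cc1F`: 2.2 mL/min
compound 3, `N#Cc1cccc(S(=O)(=O)c2cnc3c(F)cccc3c2-c2ccc(Cl)cc2)c1`: 0.08 mL/min

All three were tested in an ADME assay on microsomes from liver (Homo sapiens) for metabolic stability, tested at 2.5 uM; a higher number here means faster removal of the compound, a lower number slower removal. Compound 2 and compound 3 differ in their cores: 3-cyanophenyl in place of 3-fluoro-4-methylphenyl on a sulfonyl sulfur, a step of a 28-fold lower number from compound 2 to compound 3 (1.44 log units; beyond the scatter). Within the core of compound 2, the change to compound 1 is fluoro in place of chloro on an aromatic carbon, which gave a 1.3-fold higher number from compound 2 to compound 1 (0.10 log units; within the scatter).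

Compound 4, `N#Cc1cccc(S(=O)(=O)c2cnc3c(F)cccc3c2-c2ccc(F)cc2)c1`, has not yet been measured. Its difference from compound 3 is fluoro in place of chloro on an aromatic carbon; the surroundings of the place are described in the same words as for compound 1 and compound 2, so this is the same change, now on the core of compound 3. In this assay the step from compound 3 to compound 4 is expected to be a 1.3-fold higher number from compound 3 to compound 4 (0.10 log units; within the scatter), matching the earlier step and resting on a 1.3-fold higher number from compound 2 to compound 1 (0.10 log units; within the scatter). Compound 4 is therefore estimated at 0.1 mL/min, expected between 0.04 mL/min and 0.25 mL/min.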

Compound 4, intrinsic clearance in a liver preparation (reported as CLH), per the amount of preparation that the assay uses: 0.19 mL/min
Compound 4: the middle estimate sits 1.9-fold (0.28 log units) below what was measured, and the stated range covers the measured number.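

In this assay, fluoro in place of chloro gave a 2.4-fold higher number from compound 3 to compound 4 (0.38 log units; beyond the scatter), and set beside the earlier step on the other core, the two do not differ: the same change on two cores in this assay, a 1.3-fold higher number (0.10 log units; within the scatter) from compound 2 to compound 1 and a 2.4-fold higher number (0.38 log units; beyond the scatter) from compound 3 to compound 4, 1.9-fold (0.28 log units) apart, within the scatter of two such steps. Read the other way, 3-cyanophenyl in place of 3-fluoro-4-methylphenyl gave a 14-fold lower number from compound 1 to compound 4 (1.16 log units; beyond the scatter), and this large step also agrees with its earlier counterpart: the same change on two cores in this assay, a 28-fold lower number (1.44 log units; beyond the scatter) from compound 2 to compound 3 and a 14-fold lower number (1.16 log units; beyond the scatter) from compound 1 to compound 4, 1.9-fold (0.28 log units) apart, within the scatter of two such steps. This shows that both changes carried across these two cores, but it rests on a single pair of cores and does not show that they would carry to any other core or why they behave this way.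

The compounds shown leave open how a methyl or methoxy group would read in place of the chloro or fluoro. They also leave open what an amine or a carboxylic acid on the sulfonyl aryl ring would do.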